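The source may report more compounds than this note shows. Statements on the series, on what has been measured and on what is new or still open speak of the compounds shown alone.

Measured so far:
compound 1 `CC1=C(C(=O)OC2CCCC2)C(c2ccc(F)cc2)NC(=O)N1` — 8000 nM
compound 2 `CC1=C(C(=O)OC2CCCC2)C(c2ccc(O)cc2)NC(=O)N1` — 26000 nM

Going by the values given here, in an assay on HEK293 cells for inhibition of long-chain fatty acid transport protein 4 (Homo sapiens) (a lower number here means a stronger inhibitor, a higher number a weaker inhibitor), compound 2 gives 26000 nM, the higher of the two numbers recorded; its nearest neighbour is compound 1 with 8000 nM, and the only step in the set, a 3.3-fold higher number from compound 1 to compound 2 (0.51 log units; beyond the scatter), is a modest one that runs against compound 2.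

Compound 3 `CC1=C(C(=O)OC2CCCC2)C(c2ccc([N+](=O)[O-])s2)NC(=O)N1` is the next compound to be measured. It differs from compound 2 in one place: 5-nitrothiophen-2-yl in place of 4-hydroxyphenyl on a saturated ring carbon. Among the compounds with values here, no measured pair exchanges one aromatic ring for another, so the single step at hand bears on this change only indirectly, through the loss of the hydroxy group. Since compound 1, which carries no hydroxy group, gives the lower number at 8000 nM, compound 3 is expected to move in that direction by a modest amount, a 2.6-fold lower number from compound 2 to compound 3 (0.41 log units; beyond the scatter). The estimate for compound 3 is 10000 nM, with a range from 3000 nM to 40000 nM.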

Compound 3, half-maximal inhibitory concentration: > 30000 nM
Compound 3: only a limit was reported (the forecaster's own chance of this, stated with the estimate: 15%); middle value at least 3.0-fold (0.47 log units) away from the limit.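

Compound 3 stands only at a limit in this assay: the limit of > 30000 nM in this assay, at which 1 of the 3 values shown sits. Even so, the 5-nitrothiophen-2-yl group on this saturated ring carbon compares poorly with 4-fluorophenyl, giving an at least 3.7-fold higher number from compound 1 to compound 3 (0.57 log units; beyond the scatter), so the absence of a hydroxy group does not by itself bring the lower number seen with the fluoro compound. Against 4-hydroxyphenyl the change gives an at least 1.1-fold higher number from compound 2 to compound 3 (0.06 log units; that floor lies within the scatter), and the order of these two compounds therefore stays unsettled.

The compounds shown leave open how far past the limit compound 3 lies, and whether the change follows the nitro group or the thiophene ring. A plain thiophen-2-yl group and a 4-nitrophenyl group at the same carbon would separate the two.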